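Acid dissociation in a series of aryl-substituted amines

The source may hold more compounds than are shown below. What is called first, only, known or untested is meant among the compounds shown, and "the series" means these compounds.

Three members of the series have been measured. Compound 1 is `COc1cccc(CNCCCNc2ccnc3cc(Cc4ccccc4)ccc23)c1O`, compound 2 is `COc1ccc(F)cc1CNCCCNc1ccnc2cc(-c3cccc4ccccc34)ccc12` and compound 3 is `COc1cccc(CNCCCNc2ccnc3cc(-c4ccc(F)cc4)ccc23)c1O`. In a physicochemical assay for acid dissociation, compound 1 gives 9.47. In this assay compound 2 gives 9.47. In this assay compound 3 gives 9.47. Compound 3 thus stands level with compound 1 and with compound 2 at the digits recorded, with nothing to separate the three. Among the measured compounds shown here, the only single-point step among the measured compounds is no change at the digits printed from compound 1 to compound 3 (within the scatter), so exchanging one aryl group for another at this site of the core has left the read-out where it was.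

The next compound, compound 4, is `COc1cccc(CNCCCNc2ccnc3cc(-c4cccc5ccccc45)ccc23)c1O`. Relative to compound 3 the difference is naphthalen-1-yl in place of 4-fluorophenyl on an aromatic carbon. For the measured compounds named here, this is again an exchange of one aryl group for another at the same site, and the one comparable step, from compound 1 to compound 3, was flat. On that basis no step beyond the scatter is expected here, and the expected step is no change at the digits printed from compound 3 to compound 4 (within the scatter). In this assay compound 4 is therefore estimated at 9.47. The expected range for compound 4 runs from 9.17 to 9.77.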

Compound 4, acid dissociation constant: 9.47
For compound 4 middle estimate and measured number coincide at the digits printed; the range from low to high includes it.
By their numbers in this assay, from the lowest: compounds 1, 2, 3 and 4 (each within the scatter of the next).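

In this assay, naphthalen-1-yl, with 10 heavy atoms and 2 six-membered aromatic rings of carbon only, replaces 4-fluorophenyl, with 7 heavy atoms and one such ring, and the result is no change at the digits printed from compound 3 to compound 4 (within the scatter); at this aromatic carbon, the read-out therefore does not register the added ring or the loss of fluorine. Naphthalen-1-yl in place of benzyl gives no change at the digits printed from compound 1 to compound 4 (within the scatter), so benzyl, 4-fluorophenyl and naphthalen-1-yl now stand within the scatter of one another at this site. A comparison is also now available at a second place, where 2-hydroxy-3-methoxyphenyl in place of 5-fluoro-2-methoxyphenyl on a saturated chain carbon bound to an amine nitrogen gives no change at the digits printed from compound 2 to compound 4 (within the scatter).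

No measured evidence is available to explain this flat behaviour. Still open, on these data alone, are whether a group carrying charge at this aromatic carbon, such as an amine or a carboxylic acid, would shift the read-out, whether a longer chain linking the core to the aryl-bearing amine would do so, and which proton in these compounds the read-out reports.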